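Methoxy Addition on the Aryl Imine of Compound 1

The source may report more compounds than this note shows. Statements on the series, on what has been measured and on what is new or still open speak of the compounds shown alone.

Measured so far:
- compound 1, `COc1ccc(/C=N/c2c(C)n(C)n(-c3ccccc3)c2=O)cc1`: 575000000 nM
- compound 2, `Cc1c(/N=C/c2ccccc2Cl)c(=O)n(-c2ccccc2)n1C`: 851000000 nM

In a functional assay on HCT-116 cells (Homo sapiens) for cytotoxicity, read by MTT assay, with a stated time of 72 h (on this read-out higher numbers stand for weaker inhibition and lower numbers for stronger inhibition), compound 1 gives 575000000 nM, the lower of the two numbers in hand; compound 2 gives 851000000 nM, and a 1.5-fold higher number from compound 1 to compound 2 (0.17 log units; within the scatter), so the two are not separated. Compound 3, `COc1ccc(/C=N/c2c(C)n(C)n(-c3ccccc3)c2=O)cc1OC`, is not yet measured. It differs from compound 1 by methoxy in place of hydrogen on an aromatic carbon, the new group being placed ortho to a methoxy group and meta to a large group.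

Going by the values given here, only one measured step is available, and it concerns a different change, the exchange of the whole aryl group (a 1.5-fold higher number from compound 1 to compound 2 (0.17 log units; within the scatter)). It bears on the present step only in that a change at the aryl group left the number within the scatter. For compound 3 the step is therefore expected to be no change at the digits printed from compound 1 to compound 3 (within the scatter), with no direction beyond the scatter. Compound 3 is estimated at 575000000 nM, in the range 250000000 nM to 1300000000 nM.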

Compound 3, half-maximal inhibitory concentration: 575000000 nM
Beside the measured number, compound 3's estimate shows no gap at the digits printed; measured number inside the range.
By their numbers in this assay, from the lowest: compounds 1, 3 and 2 (each within the scatter of the next).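

Notes on the added methoxy: in this assay, methoxy in place of hydrogen on an aromatic carbon, ortho to a methoxy group and meta to a large group, gives no change at the digits printed from compound 1 to compound 3 (within the scatter), so this position on the aryl group of compound 1 takes the added group with no separation in the number. The earlier step covered only the exchange of the whole aryl group, whereas this one isolates a single added methoxy at a single place. Nothing measured here offers an explanation for this result.

Going by these compounds, whether an amine, a carboxylic acid or a longer chain at this place would separate from compound 1 stays open. Also open, on these data alone, is whether any change on the shared core, away from the aryl group, moves the number beyond the scatter.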